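The source may report more compounds than this note shows. Statements on the series, on what has been measured and on what is new or still open speak of the compounds shown alone.

Measured so far in a functional assay on CEM-SS cells (Homo sapiens) for cytotoxicity; on this read-out higher numbers stand for weaker inhibition and lower numbers for stronger inhibition:
- compound 1 `Nc1nc2cc(Cl)c(Cl)cc2n1Cc1cccc(Cl)c1`: 37000 nM
- compound 2 `Clc1cccc(Cn2c(Cl)nc3cc(Cl)c(Cl)cc32)c1`: > 100000 nM (a limit, not a number)

Compound 2 therefore has no number of its own, only the limit > 100000 nM.

The next structure, compound 3 `O=[N+]([O-])c1cccc(Cn2c(Cl)nc3cc(Cl)c(Cl)cc32)c1`, carries nitro in place of chloro on an aromatic carbon, meta to a large group: nitro in place of chloro on an aromatic carbon.

Among the measured compounds shown here, the only measured step is an at least 2.7-fold higher number from compound 1 to compound 2 (0.43 log units; beyond the scatter), for chloro in place of amino on an aromatic carbon. For the measured compounds named here, that change lies elsewhere in the molecule, so it bears on this one only loosely, and no step at the new place has been measured. Resting on an at least 2.7-fold higher number from compound 1 to compound 2 (0.43 log units; beyond the scatter), no step beyond the scatter is the likeliest outcome in this assay, with any modest move expected toward lower numbers. The expected change is an at least 1.2-fold lower number from compound 2 to compound 3 (0.09 log units; that floor lies within the scatter). For compound 3 the estimate is 80000 nM, with an expected range of 25000 nM to 150000 nM.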

Compound 3, half-maximal inhibitory concentration: > 100000 nM
Compound 3 gave a limit, no number; the forecaster's own chance of this, stated with the estimate: 60%; at least 1.2-fold (0.09 log units) between middle value and limit.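

In this assay, compound 2 and compound 3 both give a limit, not a number, so no step can be read between them: the limit of > 100000 nM in this assay, at which 2 of the 3 values shown sit.

Going by these compounds, whether nitro in place of chloro on an aromatic carbon shifts the read-out in either direction stays open.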